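Series notes: carbamoyl to isobutoxy on the shared core

This account rests on a few compounds, and the source may have more. Where it says the series, first, only, none or still open, it means among the compounds named here.

compound 1 `Clc1cncc(N2CCNCC2)c1`: 310 nM
compound 2 `c1ccc(Sc2cncc(N3CCCNCC3)c2)cc1`: 4 nM
compound 3 `NC(=O)c1cncc(N2CCCNCC2)c1`: 20 nM

In an assay on cell membranes for binding affinity to Neuronal acetylcholine receptor; alpha4/beta2 (Rattus norvegicus), read by radioligand binding (on this read-out lower numbers stand for stronger inhibition and higher numbers for weaker inhibition), compound 3 gives 20 nM, the second highest of the three numbers. Nearest stands compound 2 with 4 nM, a lower number beyond the scatter; furthest stands compound 1 with 310 nM, a higher number beyond the scatter. Within the data shown here, no pair of measured compounds differs in a single place, so no measured step is known.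

Compound 4 `CC(C)COc1cncc(N2CCCNCC2)c1` differs from compound 3 by isobutoxy in place of carbamoyl on an aromatic carbon. Going by these compounds, the step from carbamoyl to isobutoxy is untested here. Compound 2, which carries another group on its core, gives 4 nM, so a move toward lower numbers is plausible. A modest step of a 1.7-fold lower number from compound 3 to compound 4 (0.22 log units; within the scatter) toward a lower number is expected, not far beyond the scatter. Compound 4 is estimated at 12 nM, within 3 nM to 50 nM.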

Compound 4, half-maximal inhibitory concentration: 2.2 nM
Compound 4: the middle estimate sits 5.5-fold (0.74 log units) above what was measured; the whole stated range lies above it.
By their numbers in this assay, from the lowest: compounds 4 and 2 (each within the scatter of the next); then compound 3; then compound 1.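

In this assay, among these compounds, the change gives a 9.1-fold lower number from compound 3 to compound 4 (0.96 log units; beyond the scatter) and is the first single-place step on the shared core; at this aromatic carbon, two atoms from the ring nitrogen, isobutoxy gives a lower number than carbamoyl, with the hydrogen-bond donor gone. Compound 4 at 2.2 nM and compound 2 at 4 nM lie within the scatter of each other. No measurement shown accounts for the step.

Going by these compounds, whether a shorter ether such as methoxy or a primary amine at this position would give a similar number stays open. On these data alone, whether a carboxylic acid would be accepted there also stays open.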